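Replacing the bicyclic acid with a hydroxy-dioxothiane in an amide series

The compounds below may be only part of what the source reports. "The series", "measured", "known", "first", "only" and "open" are said of these compounds alone.

The study covers a shared core carrying a substituted piperidine amide, varied at the group attached to the carbonyl carbon. Compound 1 `CCC[C@]1(C(=O)N2CC[C@](c3ccc(C(F)(C(F)(F)F)C(F)(F)F)cc3)(S(=O)(=O)c3ccc(F)cc3)C2)CC[C@H](C(=O)O)CC1` was submitted to an ADME assay on microsomes from liver (Homo sapiens) for metabolic stability, with a stated time of 10 min (on this read-out higher numbers stand for a more stable compound and lower numbers for a less stable compound), and for compound 1 the entry reads "not determined" (no result reported). Compound 3 `O=C(O)C12CCC(C(=O)N3CC[C@](c4ccc(C(F)(C(F)(F)F)C(F)(F)F)cc4)(S(=O)(=O)c4ccc(F)cc4)C3)(CC1)C2` was submitted as well, and in this assay compound 3 likewise gives "not determined" (no result reported). Among the measured compounds shown here, compound 2 `C[C@]1(C(=O)N2CC[C@](c3ccc(C(F)(C(F)(F)F)C(F)(F)F)cc3)(S(=O)(=O)c3ccc(F)cc3)C2)CC[C@@H](C(=O)O)CC1`, which carries a methyl group and a carboxylic acid on its cyclohexane ring, is the only compound of the set with a number: in this assay compound 2 gives 85%. Compound 3 therefore stands without a single number, and compound 1 shares that position.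

Compound 4 `O=C(N1CC[C@](c2ccc(C(F)(C(F)(F)F)C(F)(F)F)cc2)(S(=O)(=O)c2ccc(F)cc2)C1)C1(O)CCS(=O)(=O)CC1` has not yet been measured. It differs from compound 3 in the group on the carbonyl carbon whose other neighbour is the amide-type nitrogen in a ring: a group of 9 heavy atoms (5 carbon, 3 oxygen, 1 sulfur; one six-membered non-aromatic ring with 1 hetero atom) in place of a group of 10 heavy atoms (8 carbon, 2 oxygen; 2 five-membered non-aromatic rings of carbon only), on a carbonyl carbon. For the measured compounds named here, since no step between measured compounds is available, the direction of the change cannot be read from the data; with only the value of compound 2 as a reference, a step of modest size, in either direction or none beyond the scatter, seems the most reasonable expectation. Compound 4 is estimated to give 70% in this assay, with a range from 40% to 95%.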

Compound 4, percent of the compound remaining: 100%
Estimate against measurement, compound 4: 30 percentage points below; measured number outside the range, above it.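

In this assay, among the compounds shown here, putting 4-hydroxy-1,1-dioxothian-4-yl in place of 4-carboxy-1-methylcyclohexyl on a carbonyl carbon whose other neighbour is the amide-type nitrogen in a ring gives a number 15 percentage points higher from compound 2 to compound 4 (beyond the scatter), the first readable step at this position. It shows that this position accepts a group with a sulfur-containing ring and a hydroxy group but no carboxylic acid, with compound 4 at 100% in this assay, so a carboxylic acid on this group is not required for a high value on this read-out. Nothing measured in the material at hand accounts for the rise, and the reason for it remains unknown.

All steps to or from compound 1 and compound 3 cannot be read, so the effect of the propyl group of compound 1 and of the bicyclic acid of compound 3 on this read-out stays undefined. The compounds shown also leave open whether the value of compound 4 would hold with an amine or a methoxy group in place of the hydroxy group on the 4-hydroxy-1,1-dioxothian-4-yl group.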